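The source may report more compounds than this note shows. Statements on the series, on what has been measured and on what is new or still open speak of the compounds shown alone.

Compound 1 `COc1ccc(/C=C\c2cc(OC)c(OC)c(OC)c2)cc1OCc1ccc(CN2CC[C@@H](O)C2)cc1` stands at a limit in a functional assay on B16-F10 cells (Mus musculus) for antiproliferative activity, read by CCK-8 assay, with a stated time of 48 h; a lower number here means a stronger inhibitor, a higher number a weaker inhibitor: compound 1 gives > 10000 nM, a limit rather than a number. Compound 2 `COc1ccc(/C=C\c2cc(OC)c(OC)c(OC)c2)cc1OCc1ccc(CN2CC[C@H](O)C2)cc1` also returns a limit, > 10000 nM. The step that the two limits leave unreadable from compound 1 to compound 2 is therefore unreadable, even with the fact that compounds 1 and 2 differ only in the configuration as drawn in view. Compound 3 `COc1ccc(/C=C\c2cc(OC)c(OC)c(OC)c2)cc1OCc1ccc(CNCCN(C)C)cc1` carries (2-(dimethylamino)ethyl)amino in place of 3-hydroxypyrrolidin-1-yl on a saturated chain carbon bound to an aromatic carbon. For the measured compounds named here, no measured step bears on this change, and the only evidence available is the limit of > 10000 nM in this assay, at which 2 of the 2 values shown sit, so the step of an at least 1.2-fold lower number from compound 1 to compound 3 (0.09 log units; that floor lies within the scatter) is expected to be modest, with a fair chance that only a limit is returned again. Compound 3 is estimated at 8000 nM, within 1500 nM to 30000 nM.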

Compound 3, half-maximal inhibitory concentration: > 10000 nM
Compound 3: a limit, no number; the forecaster's own chance of this, stated with the estimate: 55%; middle value at least 1.2-fold (0.09 log units) away from the limit.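

For the compounds shown here, compound 3 also stands at a limit, so with compounds 1 and 2 at limits too, no step among the three can be read in this assay. The compounds shown leave open what change to the shared core would bring a measurable number.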